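The source may report more compounds than this note shows. Statements on the series, on what has been measured and on what is new or still open speak of the compounds shown alone.

Measured compounds:
compound 1, `NCc1ccc(C(=O)OCCc2ccccc2)cc1`: 600000000 nM
compound 2, `NCc1ccc(C(=O)OCCCc2ccccc2)cc1`: 500000000 nM
compound 3, `CCCCOC(=O)c1ccc(CN)cc1`: 910000000 nM

All three were tested in an assay on isolated protein for inhibition of serine protease 1 (Homo sapiens); a lower number here means a stronger inhibitor, a higher number a weaker inhibitor. Compound 3 returns the highest of the three numbers, but the steps of a 1.5-fold higher number from compound 1 to compound 3 (0.18 log units; within the scatter) and a 1.8-fold higher number from compound 2 to compound 3 (0.26 log units; within the scatter) both sit within the scatter, so no order among the three can be claimed.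

Compound 4, `CCCCCOC(=O)c1ccc(CN)cc1`, differs from compound 3 by methyl in place of hydrogen on a saturated chain carbon, four bonds along the chain from an oxygen next to a carbonyl group. Among the measured compounds shown here, the only comparable steps are the two above, which also change the group on a saturated chain carbon of this chain, and neither moves this assay beyond the scatter. Compound 4 is therefore expected to give 900000000 nM, with a range from 400000000 nM to 2000000000 nM. The expected step is a 1.0-fold lower number from compound 3 to compound 4 (0.00 log units; within the scatter), that is, none beyond the scatter.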

Compound 4, inhibition constant: 700000000 nM
Estimate against measurement, compound 4: 1.3-fold (0.11 log units) above; measured number inside the range.
By their numbers in this assay, from the lowest: compounds 2, 1, 4 and 3 (each within the scatter of the next).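

In this assay, methyl in place of hydrogen at this position gives a 1.3-fold lower number from compound 3 to compound 4 (0.11 log units; within the scatter), so lengthening the chain by this unit shows no change beyond the scatter. Alkyl in place of phenyl also stays within the scatter, with ethyl giving a 1.4-fold higher number from compound 2 to compound 4 (0.15 log units; within the scatter) and propyl giving a 1.2-fold higher number from compound 1 to compound 4 (0.07 log units; within the scatter). The exchange of phenyl for ethyl now reads alike on two chains: the same change on two cores in this assay, a 1.5-fold higher number (0.18 log units; within the scatter) from compound 1 to compound 3 and a 1.4-fold higher number (0.15 log units; within the scatter) from compound 2 to compound 4, 1.1-fold (0.03 log units) apart, within the scatter of two such steps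

Going by these compounds, whether any group on this chain moves the number beyond the scatter remains open. An amine, a carboxylic acid or a longer chain could test this.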